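The source may report more compounds than this note shows. Statements on the series, on what has been measured and on what is new or still open speak of the compounds shown alone.

Compound 1, `CCCCn1c(Cc2cc(OC)c(OC)c(OC)c2)nc2c(N)nc(F)nc21`: 24000 nM
Compound 2, `CCCCn1c(Cc2c(Br)c(OC)c(OC)c(OC)c2Br)nc2c(N)ncnc21`: 30200 nM
Compound 3, `CC/C=C\Cn1c(Cc2cc(OC)c(OC)c(OC)c2)nc2c(N)ncnc21`: 64600 nM

All three compounds were tested in a functional assay on MCF7 cells (Homo sapiens) for antiproliferative activity; on this read-out higher numbers stand for weaker inhibition and lower numbers for stronger inhibition. They share one core, and they differ in the chain on the aromatic nitrogen and in the substituents on the two rings. Compound 3 has the highest number of the three, which here means the weakest inhibition; its gaps to compound 2 and to compound 1 both lie beyond the usual scatter, so compound 3 is the least potent of the set on this read-out.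

Compound 4, `CCCCCn1c(Cc2cc(OC)c(OC)c(OC)c2)nc2c(N)ncnc21`, has not yet been measured in this assay. It differs from compound 3 in one place: butyl in place of but-1-en-1-yl on a saturated chain carbon bound to an aromatic nitrogen. The chain keeps its count of carbon atoms; only the double bond outside aromatic rings is gone, giving a fully saturated chain on the aromatic nitrogen. Going by the values given here, no two measured compounds differ in exactly this way, so the expected step rests on compound 1, whose butyl chain gives 24000 nM with an added fluorine on the core, a lower number than compound 3. From that, a small move toward lower numbers is expected, of a size that may not exceed the scatter: a 1.8-fold lower number from compound 3 to compound 4 (0.27 log units; within the scatter). Compound 4 is estimated at 35000 nM, within 12000 nM to 100000 nM.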

Compound 4, half-maximal inhibitory concentration: 61700 nM
Estimate against measurement, compound 4: 1.8-fold (0.25 log units) below; the range from low to high includes it.
By their numbers in this assay, from the lowest: compounds 1 and 2 (each within the scatter of the next); then compounds 4 and 3 (each within the scatter of the next).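

In this assay, saturating the chain on the aromatic nitrogen gives a 1.0-fold lower number from compound 3 to compound 4 (0.02 log units; within the scatter), so pent-2-en-1-yl and pentyl cannot be told apart on this read-out. Going by these compounds alone, this is the first pair in the set that differs in one place, and it shows that at this position, with everything else held the same, losing the double bond outside the aromatic rings leaves the number within the usual scatter. Nothing available here bears on why this is so.

The compounds shown leave open whether a shorter chain such as ethyl, a longer chain such as octyl, or a chain ending in an amine or a carboxylic acid would move the number at this position. They also leave open whether the same change would read alike with the fluorine of compound 1 or the two bromines of compound 2 in place.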